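Amine exchange on the shared core, chloro aryloxyacetamide

This account rests on a few compounds, and the source may have more. Where it says the series, first, only, none or still open, it means among the compounds named here.

Two measured compounds frame the step. Compound 1 `CCC1(O)CCN(c2nc(C)c3cc(NC(=O)COc4ccc(OC(F)(F)F)cc4)ccc3n2)CC1` and compound 2 `CCN1CCN(c2nc(C)c3cc(NC(=O)COc4ccc(Cl)cc4)ccc3n2)CC1` share a core but differ in two places, the amine on the core and the substituent on the aryloxy ring. In an assay on CHO-K1 cells for displacement of a labelled ligand from melanin-concentrating hormone receptor 1 (Homo sapiens), with a stated time of 2 h (on this read-out lower numbers stand for stronger inhibition and higher numbers for weaker inhibition), compound 1 gives 116 nM. In this assay compound 2 gives 690 nM, the higher of the two numbers, and its gap to compound 1 lies beyond the scatter. Because the two differ in two places, the share of each place in that gap cannot be read from these numbers alone.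

Compound 3 `CCC1(O)CCN(c2nc(C)c3cc(NC(=O)COc4ccc(Cl)cc4)ccc3n2)CC1` keeps the chloro aryloxyacetamide of compound 2 and takes the amine of compound 1: 4-ethyl-4-hydroxypiperidin-1-yl in place of 4-ethylpiperazin-1-yl on an aromatic carbon. Among the measured compounds shown here, no step between measured compounds isolates this exchange. The expectation is a move toward the lower number, because the same amine appears in compound 1 with 116 nM, while the remaining uncertainty is carried by the untested aryloxy pairing. The estimated step is a 4.1-fold lower number from compound 2 to compound 3 (0.61 log units; beyond the scatter), beyond the scatter. Compound 3 is expected at 170 nM, within 55 nM to 520 nM.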

Compound 3, half-maximal inhibitory concentration: 208 nM
Compound 3: the middle estimate sits 1.2-fold (0.09 log units) below what was measured, within the range that was stated.
By their numbers in this assay, from the lowest: compounds 1 and 3 (each within the scatter of the next); then compound 2.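

With the chloro aryloxyacetamide held fixed in this assay, 4-ethyl-4-hydroxypiperidin-1-yl in place of 4-ethylpiperazin-1-yl on the aromatic carbon between two ring nitrogen atoms gives a 3.3-fold lower number from compound 2 to compound 3 (0.52 log units; beyond the scatter) and thus isolates the amine exchange as a modest step beyond the scatter at this position. With 4-ethyl-4-hydroxypiperidin-1-yl held fixed, chloro in place of trifluoromethoxy on the aryloxy ring gives a 1.8-fold higher number from compound 1 to compound 3 (0.25 log units; within the scatter) in this assay and stays within the scatter, so this assay does not separate these two substituents on this amine. No measurement other than these binding numbers is available to account for either step.

From the compounds shown here alone, it remains open whether the amine step follows the hydroxyl group, the ethyl group or the replaced ring nitrogen, which 4-ethylpiperidin-1-yl and 4-hydroxypiperidin-1-yl on the shared core would help to separate. Going by these compounds, it also remains open whether chloro and trifluoromethoxy stay within the scatter of each other with 4-ethylpiperazin-1-yl on the core, and how a fluoro or cyano group on the aryloxy ring would compare.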